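The source may report more compounds than this note shows. Statements on the series, on what has been measured and on what is new or still open speak of the compounds shown alone.

Compound 2 `COc1cccc(/C=C/C(=O)c2sc(Nc3ccc(Cl)cc3)nc2C)c1` is one of two compounds tested in a functional assay on PC-3 cells (Homo sapiens) for cytotoxicity, read by MTT assay; on this read-out higher numbers stand for weaker inhibition and lower numbers for stronger inhibition. In this assay compound 2 gives > 25000 nM, which is a limit of the assay rather than a number. Compound 1 `COc1ccc(/C=C/C(=O)c2sc(Nc3ccc(Cl)cc3)nc2C)cc1` likewise gives only a limit, > 25000 nM. The step that the two limits leave unreadable from compound 1 to compound 2 therefore cannot be read. Compound 3 `COc1cccc(/C=C/C(=O)c2sc(Nc3ccc(Cl)c(Cl)c3)nc2C)c1` differs from compound 2 by chloro in place of hydrogen on an aromatic carbon. Among the measured compounds shown here, no measured step bears on this change, and both values shown sit at the limit (the limit of > 25000 nM in this assay, at which 2 of the 2 values shown sit). Compound 3 is therefore expected to stay near that limit, with an estimated 30000 nM ranging from 8000 nM to 100000 nM. This corresponds to an expected step that the limit leaves unreadable from compound 2 to compound 3.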

Compound 3, half-maximal inhibitory concentration: 10100 nM
Compound 3: the middle estimate sits 3.0-fold (0.47 log units) above what was measured; the range from low to high includes it.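

In this assay, among the compounds shown here, turning the 4-chlorophenyl of compound 2 into 3,4-dichlorophenyl gives an at least 2.4-fold lower number from compound 2 to compound 3 (0.39 log units; beyond the scatter), the first step that can be read at all, since the step between the two limits could not. A chloro on this aromatic carbon, ortho to the existing chloro group, thus brings a measurable value. Compound 2 gives only a limit, so this step has a lower bound and no exact size: the limit of > 25000 nM in this assay, at which 2 of the 3 values shown sit.

Going by these compounds, whether a methyl, a methoxy or an amine at this carbon would do the same remains open. So does whether this chloro would have a similar effect with the 4-methoxyphenyl of compound 1.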